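The source may hold more compounds than are shown below. What is called first, only, known or untested is meant among the compounds shown, and "the series" means these compounds.

In a functional assay on SK-MEL-28 cells (Homo sapiens) for inhibition (a lower number here means a stronger inhibitor of growth, a higher number a weaker inhibitor of growth), compound 1 (`O=C(/C=C/c1cccc(O)c1)c1cccc(-n2cc(-c3ccccc3)[nH]c2=O)c1`) gives 5630 nM and compound 2 (`O=C(/C=C/c1cccc(O)c1)c1cccc(-n2cc(-c3ccc(Cl)cc3)[nH]c2=O)c1`) gives 3640 nM. These two numbers lie within the scatter of each other, so compound 2 stands level with compound 1. Compound 3 (`COc1cc(/C=C/C(=O)c2cccc(-n3cc(-c4ccc(Cl)cc4)[nH]c3=O)c2)ccc1O`) differs from compound 2 in one group: 4-hydroxy-3-methoxyphenyl in place of 3-hydroxyphenyl on a double-bonded chain carbon bound to a double-bonded chain carbon. Within the data shown here, the only measured step, a 1.5-fold lower number from compound 1 to compound 2 (0.19 log units; within the scatter), concerns a different place, so it offers no guide to this change, and no step beyond the scatter is expected. The estimated step is a 1.2-fold lower number from compound 2 to compound 3 (0.08 log units; within the scatter). For compound 3 the expected value is 3000 nM, with an estimated range from 1000 nM to 9000 nM.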

Compound 3, concentration for 50% growth inhibition: 2060 nM
For compound 3 the middle estimate is 1.5-fold (0.16 log units) above the measured one; the range from low to high includes it.
By their numbers in this assay, from the lowest: compounds 3, 2 and 1 (each within the scatter of the next, the first and the last beyond it).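

The group on the double-bonded chain carbon had stayed the same until now, and replacing 3-hydroxyphenyl with 4-hydroxy-3-methoxyphenyl gives a 1.8-fold lower number from compound 2 to compound 3 (0.25 log units; within the scatter) in this assay. So this position accepts a larger group, with one more hydrogen-bond acceptor, without a shift beyond the scatter. Nothing available explains how this swap acts on the cells. Still open, as far as these compounds go, is whether an amine or a carboxylic acid on that aromatic ring would shift the number beyond the scatter. Also open, from the compounds shown here alone, is whether the same swap would give a similar step on compound 1, which carries hydrogen in place of chloro.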